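This account rests on a few compounds, and the source may have more. Where it says the series, first, only, none or still open, it means among the compounds named here.

Compound 1 `CC(CSc1ccc(F)cc1)C(=O)Nc1ccc([N+](=O)[O-])cc1C(F)(F)F` was tested in a functional assay on LNCaP cells (Homo sapiens) for antiproliferative activity, read by MTT assay, with a stated time of 96 h (on this read-out higher numbers stand for weaker inhibition and lower numbers for stronger inhibition), and gives 43200 nM. Compound 2 `CC(CSc1ccc(C(F)(F)F)cc1)C(=O)Nc1ccc([N+](=O)[O-])cc1C(F)(F)F` differs from it by trifluoromethyl in place of fluoro on an aromatic carbon, and in this assay compound 2 gives 54300 nM, which is a 1.3-fold higher number from compound 1 to compound 2 (0.10 log units; within the scatter). Compound 3 `CC(CS(=O)(=O)c1ccc(F)cc1)C(=O)Nc1ccc([N+](=O)[O-])cc1C(F)(F)F` carries a different core; the difference between the core of compound 1 and the core of compound 3 is not broken down here. In this assay compound 3 gives 4050 nM, the lowest of the three numbers and clearly separated from the other two. Compound 4 `CC(CS(=O)(=O)c1ccc(C(F)(F)F)cc1)C(=O)Nc1ccc([N+](=O)[O-])cc1C(F)(F)F` has not yet been measured. It stands to compound 3 as compound 2 stands to compound 1: the change is trifluoromethyl in place of fluoro on an aromatic carbon, at the same kind of place on the same kind of ring, so it is the same change seen once before. The step is expected to be a 1.3-fold higher number from compound 3 to compound 4 (0.11 log units; within the scatter), because the same change earlier gave a 1.3-fold higher number from compound 1 to compound 2 (0.10 log units; within the scatter). On that basis compound 4 is expected to give about 5200 nM, with a likely range from 2600 nM to 11000 nM.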

Compound 4, half-maximal inhibitory concentration: 26300 nM
Compound 4: middle estimate off by 5.1-fold (0.70 log units), on the low side; measured number outside the range, above it.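

In this assay, putting trifluoromethyl in place of fluoro on the core of compound 3 weakens inhibition, with a 6.5-fold higher number from compound 3 to compound 4 (0.81 log units; beyond the scatter). Within the data shown here, the same swap on the core of compound 1 has a clearly different outcome, so its size cannot simply be carried from one core to the other: the same change on two cores in this assay, a 1.3-fold higher number (0.10 log units; within the scatter) from compound 1 to compound 2 and a 6.5-fold higher number (0.81 log units; beyond the scatter) from compound 3 to compound 4, 5.2-fold (0.71 log units) apart, beyond the scatter of two such steps This shows that the effect of the swap depends on the core it sits on, but it rests on only two matched pairs, and it does not show what in the cores produces the gap or how the swap would behave on a third core.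

On these data alone, it remains open how other groups at that same place on the aromatic ring, such as chloro, a nitrile or an amine, would compare on these two cores. As far as these compounds go, it is also open whether the gap between the two cores would persist if the nitro group were replaced by, for example, a carboxylic acid.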